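A few compounds are considered here, and "the series" means these few. Any claim that something is new, unique, unknown or untested is made for them only; others in the source may bear on it.

Compound 2 `COc1cc(-c2nn(-c3cccc(NC(=O)c4cccc(C(F)(F)F)c4)c3)cc2-c2ccncc2)ccc1Cl` carries an amide. In a functional assay on M14 cells (Homo sapiens) for inhibition, read by sulforhodamine B assay, with a stated time of 48 h (on this read-out higher numbers stand for lower toxicity in this test and lower numbers for higher toxicity in this test), compound 2 gives only a limit of the assay, > 50000 nM. Compound 1 `COc1cc(-c2nn(-c3cccc(NC(=O)Nc4cc(C(F)(F)F)cc(C(F)(F)F)c4)c3)cc2-c2ccncc2)ccc1Cl`, a urea bearing two trifluoromethyl groups, likewise gives only a limit in this assay, > 50000 nM. Within the data shown here, both readings sit at the limit of > 50000 nM in this assay, at which 2 of the 2 values shown sit, so no measured step between them exists. Compound 3 `COc1cc(-c2nn(-c3cccc(NC(=O)Nc4cccc(C(F)(F)F)c4)c3)cc2-c2ccncc2)ccc1Cl` differs from compound 2 by (3-(trifluoromethyl)phenyl)amino in place of 3-(trifluoromethyl)phenyl on a carbonyl carbon. Because compound 2 reaches only > 50000 nM in this assay, the step from compound 2 to compound 3 is expected to be a number no higher from compound 2 to compound 3 (the limit leaves the size open), nothing beyond the scatter. Compound 3 is therefore estimated at 50000 nM, between 25000 nM and 100000 nM, most likely again as a limit only.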

Compound 3, concentration lethal to 50% of the cells: 4650 nM
Compound 3: middle estimate off by 11-fold (1.03 log units), on the high side; measured number outside the range, below it.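

In this assay, compound 3 is the only one of the three shown to give a number rather than a limit: the limit of > 50000 nM in this assay, at which 2 of the 3 values shown sit. On a carbonyl carbon, (3-(trifluoromethyl)phenyl)amino in place of 3-(trifluoromethyl)phenyl gives an at least 10-fold lower number from compound 2 to compound 3 (1.03 log units; beyond the scatter), so the amide and the urea part ways at this position. Hydrogen in place of trifluoromethyl on an aromatic carbon gives an at least 10-fold lower number from compound 1 to compound 3 (1.03 log units; beyond the scatter), so the urea alone does not set the number. What the compounds shown leave open is whether a nitrile in place of the remaining trifluoromethyl would give a similar number.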